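The compounds below may be only part of what the source reports. "The series", "measured", "known", "first", "only" and "open" are said of these compounds alone.

Measured compounds:
compound 1, `COc1ccc(OC(=O)C#Cc2ccccc2)cc1`: 6660 nM
compound 2, `O=C1C=CC2(C=C1)OC(=O)C(c1cc3ccccc3o1)=C2c1ccccc1`: 21200 nM
compound 3, `COc1cc(C2=C(c3ccccc3)C3(C=CC(=O)C=C3)OC2=O)cc(OC)c1OC`: 9730 nM

In a functional assay on MDA-MB-231 cells (Homo sapiens) for antiproliferative activity, read by MTT assay, with a stated time of 48 h (on this read-out lower numbers stand for stronger inhibition and higher numbers for weaker inhibition), compound 2 gives the highest number of the three. Compound 3 stands nearest to it with a lower number, and that gap lies beyond the scatter; compound 1 stands furthest from it, again with a lower number beyond the scatter. For the measured compounds named here, no pair of these three differs in only one place, so no single step among measured compounds can be read off.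

Compound 4, `COc1ccc(F)cc1C1=C(c2ccccc2)C2(C=CC(=O)C=C2)OC1=O`, has not yet been measured in this assay. It differs from compound 2 by 5-fluoro-2-methoxyphenyl in place of 1-benzofuran-2-yl on a double-bonded ring carbon. The shared core of compound 2 and compound 4 is kept; compound 3 carries a differently substituted six-membered aromatic ring at the same position and gives 9730 nM, a lower number than compound 2.

On that basis a small step downward is expected from compound 2 to compound 4, a 2.7-fold lower number from compound 2 to compound 4 (0.42 log units; beyond the scatter), not far beyond the scatter. For compound 4 the estimate in this assay is 8000 nM, with a range from 3000 nM to 22000 nM.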

Compound 4, half-maximal inhibitory concentration: 10000 nM
The estimate for compound 4 lay 1.3-fold (0.10 log units) below the measured number, and the stated range covers the measured number.
By their numbers in this assay, from the lowest: compounds 1, 3 and 4 (each within the scatter of the next); then compound 2.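

In this assay, for the compounds shown here, the double-bonded ring carbon two ring bonds from the ring oxygen gives the only readable step: 5-fluoro-2-methoxyphenyl in place of 1-benzofuran-2-yl gives a 2.1-fold lower number from compound 2 to compound 4 (0.33 log units; beyond the scatter), a modest change with the shared core kept. This shows that the number at this position responds to the group it carries, and that a substituted six-membered aromatic ring can stand there in place of the fused pair of rings; compound 3 at 9730 nM and compound 4 at 10000 nM lie within the scatter of each other, so the two different substitution patterns on that ring cannot be ranked. Nothing measured here accounts for the step.

The compounds shown do not separate the share of the fluorine from that of the methoxy group within 5-fluoro-2-methoxyphenyl, since neither appears alone on this ring. They also leave open how this position would respond to a non-aromatic group such as a primary amine, a carboxylic acid or a longer alkyl chain, and whether the phenyl group on the neighbouring ring atom can be changed.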